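The compounds below may be only part of what the source reports. "The series", "measured", "known", "first", "only" and "open" are said of these compounds alone.

In a functional assay on SK-OV-3 cells (Homo sapiens) for antiproliferative activity, read by MTT assay, with a stated time of 72 h (a higher number here means a weaker inhibitor, a lower number a stronger inhibitor), three compounds sharing one core have been measured. Compound 1 `CC(C)(C)NC(=O)CCc1cccc2c1B(O)OC2` gives > 100000 nM, which is a limit of the assay and not a number. Compound 3 `Cc1cc(C)c(NC(=O)CCc2cccc3c2B(O)OC3)c(C)c1` gives 19000 nM, while compound 2 `CC(C)c1cccc(NC(=O)CCc2cccc3c2B(O)OC3)c1` gives 510 nM, the lower of the two actual numbers, with a gap beyond the usual scatter. Compound 4 `O=C(CCc1cccc2c1B(O)OC2)Nc1cccc(-c2ccc(Cl)cc2)c1` carries 4-chlorophenyl in place of the isopropyl of compound 2, on an aromatic carbon: 4-chlorophenyl in place of isopropyl on an aromatic carbon. Going by the values given here, no measured pair shows a change of this kind, so the expectation is a loose one: no step beyond the scatter. The expected step is a 1.3-fold lower number from compound 2 to compound 4 (0.11 log units; within the scatter). For compound 4, the estimated value is 400 nM, within an expected range from 80 nM to 2500 nM.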

Compound 4, half-maximal inhibitory concentration: 220 nM
Compound 4: middle estimate off by 1.8-fold (0.26 log units), on the high side, and the stated range covers the measured number.
By their numbers in this assay, from the lowest: compound 4; then compound 2; then compound 3. At a limit, above all of these: compound 1.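

In this assay, replacing isopropyl with 4-chlorophenyl on this aromatic carbon, meta to a large group, gives a 2.3-fold lower number from compound 2 to compound 4 (0.37 log units; beyond the scatter). This is the first pair shown that differs in one place, and it shows that this position accepts a larger group carrying an added aromatic ring without a loss of activity. Nothing shown bears on the reason for this step. Going by these compounds, whether the added ring or its chlorine matters remains open. Plain phenyl would separate the two, while a pyridine ring or a carboxylic acid at this position remains untested here.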